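Trifluoromethyl for Chloro in Two Chloro-Isatin Cores

The compounds below may be only part of what the source reports. "The series", "measured", "known", "first", "only" and "open" are said of these compounds alone.

Measured compounds in an ADME assay on 184B5 cells (Homo sapiens) for cytotoxicity, read by sulforhodamine B assay, with a stated time of 48 h; a higher number here means a weaker inhibitor of growth, a lower number a stronger inhibitor of growth:
compound 1 `O=C1C(=O)N(CN2CCN(c3ccnc4cc(Cl)ccc34)CC2)c2cccc(Cl)c21` gives 77700 nM
compound 2 `O=C1C(=O)N(CN2CCN(c3ccnc4cc(Cl)ccc34)CC2)c2cc(Cl)ccc21` gives 47500 nM
compound 3 `O=C1C(=O)N(CN2CCN(c3ccnc4cc(C(F)(F)F)ccc34)CC2)c2cccc(Cl)c21` gives 47400 nM

Compound 1 and compound 2 share the same atoms joined differently; the difference between the two cores is not broken down here. Compound 3 arises from compound 1 by the change (trifluoromethyl in place of chloro on an aromatic carbon), and this step gave a 1.6-fold lower number from compound 1 to compound 3 (0.21 log units; within the scatter). Compound 4 `O=C1C(=O)N(CN2CCN(c3ccnc4cc(C(F)(F)F)ccc34)CC2)c2cc(Cl)ccc21`, not yet measured, arises from compound 2 by the change (trifluoromethyl in place of chloro on an aromatic carbon), the same change at the same place. Because a 1.6-fold lower number from compound 1 to compound 3 (0.21 log units; within the scatter) lies within the scatter, the step from compound 2 to compound 4 is expected to be of similar size, estimated as a 1.6-fold lower number from compound 2 to compound 4 (0.20 log units; within the scatter). Compound 4 is therefore expected to give about 30000 nM, with a likely span from 15000 nM to 75000 nM.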

Compound 4, concentration for 50% growth inhibition: 25300 nM
The estimate for compound 4 lay 1.2-fold (0.07 log units) above the measured number; the measured number falls inside the stated range.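

In this assay, trifluoromethyl in place of chloro on an aromatic carbon gave a 1.9-fold lower number from compound 2 to compound 4 (0.27 log units; within the scatter). Set beside the earlier step, the change carried across the two cores with no difference that can be told apart: the same change on two cores in this assay, a 1.6-fold lower number (0.21 log units; within the scatter) from compound 1 to compound 3 and a 1.9-fold lower number (0.27 log units; within the scatter) from compound 2 to compound 4, 1.1-fold (0.06 log units) apart, within the scatter of two such steps. Among the compounds shown here, this shows only that the two steps agree on these two cores in this one assay; since each step lies within the scatter, it does not show that the change has any real effect on the number, nor that it would carry to a further core.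

The compounds shown leave open how a nitrile, a methoxy group or an amine would read at this place. They also leave open what replacing the remaining chloro of each core would do.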